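Swapping the pyrazole cap for an isoxazole cap

A few compounds are considered here, and "the series" means these few. Any claim that something is new, unique, unknown or untested is made for them only; others in the source may bear on it.

Measured compounds and their values in a functional assay on the whole organism (strain C57BL/6) for inhibition, with Mus musculus as the target, read by microscopy, with a stated time of 6 days, at a dose of 10 mg/kg by the oral route; on this read-out lower numbers stand for less inhibition and higher numbers for more inhibition at the one dose given (going by the name of the read-out):
- compound 1, `CC(C)c1cc(NC(=O)n2ccc3cc(Oc4ncnc5c4CCNC5)ccc32)n[nH]1`: 0%
- compound 2, `CC(C)(C)c1cc(NC(=O)n2ccc3cc(Oc4ncnc5c4CCNC5)ccc32)n[nH]1`: 0%
- compound 3, `CC1(c2cc(NC(=O)n3ccc4cc(Oc5ncnc6c5CCNC6)ccc43)n[nH]2)CC1`: 64%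

Compound 3 stands highest of the three; compound 1 and compound 2 both sit far below it, and the steps of a number 64 percentage points higher from compound 1 to compound 3 (beyond the scatter) and a number 64 percentage points higher from compound 2 to compound 3 (beyond the scatter) are large, while the step of no change at the digits printed from compound 1 to compound 2 (within the scatter) stays within the scatter.

Compound 4, `CC(C)(C)c1cc(NC(=O)n2ccc3cc(Oc4ncnc5c4CCNC5)ccc32)no1`, has not yet been measured. Its change from compound 3 is 5-(tert-butyl)-1,2-oxazol-3-yl in place of 5-(1-methylcyclopropyl)-1H-pyrazol-3-yl on an amide-type nitrogen. Two things move at once: the 1-methylcyclopropyl group becomes tert-butyl, and the pyrazole becomes a 1,2-oxazole. The first part mirrors the measured step of a number 64 percentage points higher from compound 2 to compound 3 (beyond the scatter) run backwards, which suggests a large drop. From the compounds shown here alone, nothing measured speaks to the ring change, so its effect is unknown. Compound 4 is therefore expected to fall well below compound 3, with the step estimated as a number 54 percentage points lower from compound 3 to compound 4 (beyond the scatter). The expected value for compound 4 is 10%, within a range from 0% to 45%.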

Compound 4, a percentage reported as inhibition, in the whole organism at one dose (the size of the read-out at that dose, not a potency): 83%
Beside the measured number, compound 4's estimate is 73 percentage points below it; measured number above the stated range.
By their numbers in this assay, from the lowest: compounds 1 and 2 (each within the scatter of the next); then compound 3; then compound 4.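

Within this assay, the cleanest comparison keeps tert-butyl fixed and exchanges only the pyrazole for the 1,2-oxazole, giving a number 83 percentage points higher from compound 2 to compound 4 (beyond the scatter) and showing that a tert-butyl group that reads zero on the pyrazole can read high on the 1,2-oxazole. The other two steps, a number 19 percentage points higher from compound 3 to compound 4 (beyond the scatter) and a number 83 percentage points higher from compound 1 to compound 4 (beyond the scatter) in turn, change the ring and the alkyl group together, so neither can be divided between those two changes. Nothing available explains the rise, including whether the loss of the pyrazole's hydrogen-bond donor plays any part.

From the compounds shown here alone, whether isopropyl or 1-methylcyclopropyl on the 1,2-oxazole would match tert-butyl remains open. So does the effect of placing a primary amine or a carboxylic acid on that ring in place of tert-butyl.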